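The source may hold more compounds than are shown below. What is called first, only, known or untested is meant among the compounds shown, and "the series" means these compounds.

Measured so far in an assay on isolated protein for inhibition of DNA topoisomerase 1 (Homo sapiens), with a stated time of 30 min, tested at 100 uM; a lower number here means less inhibition, a higher number more inhibition at the concentration tested (going by the name of the read-out):

- compound 1, `Cc1ccsc1-c1cc(-c2ccoc2)cc(-c2ccco2)n1`: 5.4%
- compound 2, `Clc1ccc(-c2cc(-c3ccoc3)cc(-c3ccco3)n2)s1`: 9.6%
- compound 3, `Cc1ccccc1-c1cc(-c2ccoc2)cc(-c2ccc(Cl)s2)n1`: 4.6%

Compound 3 holds the lowest of the three numbers in this assay. The step of a number 5 percentage points lower from compound 2 to compound 3 (within the scatter) lies within the scatter, as does the step of a number 4.2 percentage points higher from compound 1 to compound 2 (within the scatter), so the three measured compounds are not separated from one another by anything beyond repeat-measurement noise.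

Compound 4, `Clc1cccc(-c2cc(-c3ccoc3)cc(-c3ccc(Cl)s3)n2)c1`, has not yet been measured. Its change relative to compound 3: 3-chlorophenyl in place of 2-methylphenyl on an aromatic carbon. The group sits on an aromatic carbon of a six-membered aromatic ring with 1 nitrogen, next to the ring nitrogen, meta to a 5-chlorothiophen-2-yl group and meta to a furan-3-yl group.

Within the data shown here, the one measured step at this same position is a number 5 percentage points lower from compound 2 to compound 3 (within the scatter), and it stayed within the scatter; the step at the other position, a number 4.2 percentage points higher from compound 1 to compound 2 (within the scatter), did the same. Nothing measured here points to a step beyond the scatter, so no change beyond the scatter is expected, in either direction. Compound 4 is therefore estimated at 6%, with a range from 0% to 15%, which means an expected step of a number 1.4 percentage points higher from compound 3 to compound 4 (within the scatter).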

Compound 4, a percentage reported as inhibition, at one concentration (the size of the read-out at that concentration, not a potency): 2.1%
Beside the measured number, compound 4's estimate is 3.9 percentage points above it, within the range that was stated.
By their numbers in this assay, from the lowest: compounds 4, 3, 1 and 2 (each within the scatter of the next).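

In this assay, replacing 2-methylphenyl with 3-chlorophenyl on the aromatic carbon next to the ring nitrogen gives a number 2.5 percentage points lower from compound 3 to compound 4 (within the scatter) and shows that a chlorine in place of a methyl, on a phenyl group of the same heavy-atom count, does not separate the two compounds. Set against furan-2-yl at the same position, 3-chlorophenyl gives a number 7.5 percentage points lower from compound 2 to compound 4 (within the scatter) and leaves this position with furan-2-yl and two substituted phenyl groups, none separated by a step beyond the scatter. No evidence available here accounts for these results.

The groups shown at this position are all aromatic rings with no net charge, so the effect of an amine or a carboxylic acid there remains open. Going by these compounds, every number comes from one tested concentration, so any difference in potency across the series also remains open.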